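The source may hold more compounds than are shown below. What is called first, only, known or untested is meant among the compounds shown, and "the series" means these compounds.

In an assay on COS-7 cells for inhibition of patatin-like phospholipase domain-containing protein 2 (Mus musculus) (on this read-out higher numbers stand for weaker inhibition and lower numbers for stronger inhibition), the measured compounds stand as follows.
Compound 1 `CCOC(=O)c1cccc(-c2ccc(O)cc2)c1` gives 100000 nM.
Compound 2 `CCOC(=O)c1cccc(-c2ccc(C)cc2)c1` gives 140000 nM.
Compound 3 `CCOC(=O)c1cccc(-c2ccc(CN3CCCC3)cc2)c1` gives > 200000 nM, which is a limit of this assay rather than a number.

Compound 3 therefore sits at the limit of > 200000 nM in this assay, at which 1 of the 3 values shown sits, and only a floor is known for it. Compound 4 `CCOC(=O)c1cccc(-c2ccc(CN(C)C)cc2)c1` differs from compound 3 by dimethylamino in place of pyrrolidin-1-yl on a saturated chain carbon bound to an aromatic carbon. The measured steps that bear on this place on the molecule are an at least 1.4-fold higher number from compound 2 to compound 3 (0.15 log units; that floor lies within the scatter) and an at least 2.0-fold higher number from compound 1 to compound 3 (0.30 log units; that floor lies within the scatter), both of which end at the limit. Compound 4 keeps an amine at that chain carbon, so the step of a number no higher from compound 3 to compound 4 (the limit leaves the size open) is expected, none beyond the scatter. Compound 4 is estimated at 200000 nM, between 100000 nM and 400000 nM, and may again be reported only as a limit.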

Compound 4, half-maximal inhibitory concentration: 150000 nM
For compound 4 the middle estimate is 1.3-fold (0.12 log units) above the measured one, and the stated range covers the measured number.
By their numbers in this assay, from the lowest: compounds 1, 2 and 4 (each within the scatter of the next). At a limit, above all of these: compound 3.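

Putting dimethylamino in place of pyrrolidin-1-yl turns a limit into a real number in this assay, but the step (an at least 1.3-fold lower number from compound 3 to compound 4 (0.12 log units; that floor lies within the scatter)) shows no change beyond the scatter. Compound 4 also cannot be told apart from the two compounds without an amine, as both steps (a 1.1-fold higher number from compound 2 to compound 4 (0.03 log units; within the scatter)) and (a 1.5-fold higher number from compound 1 to compound 4 (0.18 log units; within the scatter)) stay within the scatter. Compound 3 itself remains a limit: the limit of > 200000 nM in this assay, at which 1 of the 4 values shown sits.

Still open, on these data alone, is whether any group at this place gives clearly stronger inhibition, for example a carboxylic acid or morpholin-4-yl in place of dimethylamino.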